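Chloro for cyano in a fast-cleared compound

The source may hold more compounds than are shown below. What is called first, only, known or untested is meant among the compounds shown, and "the series" means these compounds.

compound 1 `CC(C)c1ccc(S(C)(=O)=O)cc1C#Cc1cc(C#N)ccc1OCC(=O)O`: 145 mL/min/kg
compound 2 `COCCNS(=O)(=O)c1ccc(C)c(C#Cc2cc(Cl)ccc2OCC(=O)O)c1`: 33.3 mL/min/kg

Both compounds were tested in an in vivo ADME assay on the whole organism (strain BALB/c) for pharmacokinetics, with Mus musculus as the target, read by LC-MS, at a dose of 5 mg/kg by the oral route; a lower number here means slower removal, a higher number faster removal of the compound. There compound 1 stands as the higher of the two at 145 mL/min/kg, so it is removed from the body faster. Compound 2 gives 33.3 mL/min/kg, and the gap between the two lies beyond the usual scatter.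

Compound 3 `CC(C)c1ccc(S(C)(=O)=O)cc1C#Cc1cc(Cl)ccc1OCC(=O)O` keeps the core of compound 1 and changes it in one place: chloro in place of cyano on an aromatic carbon. Chloro takes the place of cyano on an aromatic carbon, para to a carboxymethoxy group.

Within the data shown here, no measured pair shows this swap on its own. Compound 2 also carries chloro, but it differs from compound 1 in other places too, so compound 2 at 33.3 mL/min/kg is only a weak hint that the number may fall. A modest downward move is therefore expected, and it may not clear the scatter. The estimate is a 1.6-fold lower number from compound 1 to compound 3 (0.21 log units; within the scatter) in this assay. For compound 3 the expected clearance is 90 mL/min/kg, with an estimated range of 45 mL/min/kg to 170 mL/min/kg.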

Compound 3, clearance: 8.33 mL/min/kg
Estimate against measurement, compound 3: 11-fold (1.03 log units) above; the measured number lies below the stated range.
By their numbers in this assay, from the lowest: compound 3; then compound 2; then compound 1.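

This one position has a large say over the number: on an aromatic carbon para to a carboxymethoxy group, chloro in place of cyano gives a 17-fold lower number from compound 1 to compound 3 (1.24 log units; beyond the scatter) in this assay and moves the compound from fast removal towards slow removal. Among these compounds, the rest of the structure is the same in both compounds, so this step is the first clean reading of the swap alone, with a cyano of two heavy atoms and a triple bond leaving and a single chlorine atom entering. The size of the step shows that the other parts of compound 1 do not settle its clearance on their own, but what lies behind the fall cannot be told from the data at hand.

A single swap cannot show whether chloro is unusual at this carbon or whether cyano is the exception, and a fluoro, a bromo, a methyl or a trifluoromethyl group there could land anywhere on this scale. From the compounds shown here alone, whether the same swap would move the number this far with other groups on the rest of the core also stays open.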